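Naphthyloxyacetyl hydrazones: from bromo to methoxy

The source may hold more compounds than are shown below. What is called first, only, known or untested is meant among the compounds shown, and "the series" means these compounds.

Compounds measured in a physicochemical assay for lipophilicity, measured as octanol-water partition; a higher number here means a more lipophilic compound, a lower number a more polar compound:
compound 1 `C/C(=N\NC(=O)COc1cccc2ccccc12)c1cccc([N+](=O)[O-])c1`, 3.37
compound 2 `O=C(COc1cccc2ccccc12)N/N=C/c1ccc(Br)cc1`, 4.81
compound 3 `C/C(=N\NC(=O)COc1cccc2ccccc12)c1ccc(O)cc1O`, 4.31

Of the compounds shown here, three sharing the same core have been measured so far. Compound 2 stands highest of the three in this assay; compound 3 is nearest and compound 1 is furthest, both lower by more than the scatter. Within the data shown here, the only measured step between two compounds that differ in one place is a number 0.94 log units higher from compound 1 to compound 3 (beyond the scatter); it concerns the aryl group on the carbon with a double bond to nitrogen and does not involve the position changed here.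

Compound 4 `COc1ccc(/C=N/NC(=O)COc2cccc3ccccc23)cc1` is not yet measured. It differs from compound 2 as follows: methoxy in place of bromo on an aromatic carbon. Read one bond further out, this is 4-bromophenyl to 4-methoxyphenyl.

Among the measured compounds shown here, no measured step in this set bears directly on this change. What can be said rests on the values of compound 2 and the general size of the shift when one small aromatic substituent replaces another. Compound 4 is therefore expected to give a lower number than compound 2, with an estimated step of a number 0.86 log units lower from compound 2 to compound 4 (beyond the scatter). The estimate for compound 4 in this assay is 3.95, with a range from 3.45 to 4.45.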

Compound 4, partition coefficient: 3.77
Beside the measured number, compound 4's estimate is 0.18 log units above it, and the stated range covers the measured number.
By their numbers in this assay, from the lowest: compound 1; then compound 4; then compound 3; then compound 2.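

Among these compounds, replacing 4-bromophenyl with 4-methoxyphenyl gives the first reading at this position: in this assay, the change on an aromatic carbon, para to a large group, produces a number 1.04 log units lower from compound 2 to compound 4 (beyond the scatter). Among the compounds shown here, the only earlier step, a number 0.94 log units higher from compound 1 to compound 3 (beyond the scatter), involved a different position and ran the other way, so this result adds that exchanging one small substituent here can by itself move the number downward beyond the scatter. The data shown offer no account of why this exchange lowers the number.

Going by these compounds, with only bromo and methoxy represented at this position, it remains open how the number in this assay would respond to other groups there, such as an amine, a carboxylic acid or a longer chain like butoxy. Also open, on these data alone, is whether replacing bromo with methoxy would bring a step of similar size and the same direction in a compound carrying the other features of compound 1 or compound 3, since this exchange has been read in a single pair.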